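The compounds below may be only part of what the source reports. "The series", "measured", "known", "first", "only" and "open" are said of these compounds alone.

Working notes on the series in an ADME assay on HEL cells (Homo sapiens) for cytotoxicity, with a stated time of 3 days; a higher number here means that more compound is tolerated, a lower number that less compound is tolerated.

Compound 1 `CCC1(Cc2ccccc2)OS(=O)(=O)C=C1OCc1ccc(Cl)cc1` gives only a limit in this assay, namely > 200000 nM. Compound 2 `CCC1(Cc2ccccc2)OS(=O)(=O)C=C1OCc1cccc(Cl)c1` gives 50000 nM in this assay. Going by the values given here, the one measured step, an at least 4.0-fold lower number from compound 1 to compound 2 (0.60 log units; beyond the scatter), moves the chloro group from one position of the ring to another and is beyond the scatter; its size is itself bounded by the fact that compound 1 sits at a limit, as noted in the limit of > 200000 nM in this assay, at which 1 of the 2 values shown sits.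

Compound 3 `CCC1(Cc2ccccc2)OS(=O)(=O)C=C1OCc1ccc(C(F)(F)F)cc1` differs from compound 1 by trifluoromethyl in place of chloro on an aromatic carbon. Among the compounds with values here, no measured step in this assay exchanges the group at this position for another group; the only step seen, an at least 4.0-fold lower number from compound 1 to compound 2 (0.60 log units; beyond the scatter), concerns the place of the chloro group, not its identity, and so does not bear directly on the change to compound 3. With no measured guide, no step beyond the scatter is expected from compound 1 to compound 3, that is a number no higher from compound 1 to compound 3 (the limit leaves the size open). Compound 3 is therefore expected to give about 200000 nM in this assay, within a range from 50000 nM to 400000 nM, with a fair chance that, as for compound 1, only a limit and no number is reported.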

Compound 3, half-maximal cytotoxic concentration: 99000 nM
Estimate against measurement, compound 3: 2.0-fold (0.31 log units) above; the measured number falls inside the stated range.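

Going by these compounds alone, the change to trifluoromethyl in place of chloro on an aromatic carbon, para to a large group, is the first to exchange the group at this position rather than move it, and in this assay it gives an at least 2.0-fold lower number from compound 1 to compound 3 (0.30 log units; that floor lies within the scatter). As far as these compounds go, that floor alone does not separate the two groups, and the true size of the step remains unknown because only a bound can be read from compound 1: the limit of > 200000 nM in this assay, at which 1 of the 3 values shown sits. With trifluoromethyl at this position, compound 3 gives a number, 99000 nM, so the position now carries a measured value, which the chloro group of compound 1 did not provide.

From the compounds shown here alone, whether the exchange of chloro for trifluoromethyl amounts to a real difference beyond the scatter stays open, and so does the effect of trifluoromethyl at the ring position held by the chloro group of compound 2. Also open, going by these compounds, is how other groups at this position, such as an amine, a carboxylic acid or a longer chain, would read in this assay.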